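Two Ring Stereocentres Flipped in a Dimeric Carbamate Series

The compounds below may be only part of what the source reports. "The series", "measured", "known", "first", "only" and "open" are said of these compounds alone.

Compound 3 `COC(=O)N[C@H](C(=O)N1CCC[C@H]1C(=O)Nc1ccc([C@@H]2CC[C@@H](c3ccc(NC(=O)[C@@H]4CCCN4C(=O)[C@@H](NC(=O)OC)C(C)C)cc3)N2c2ccc(F)cc2)cc1)C(C)C`, compound 1 `COC(=O)N[C@H](C(=O)N1CCC[C@H]1C(=O)Nc1ccc([C@H]2CC[C@H](c3ccc(NC(=O)[C@@H]4CCCN4C(=O)[C@@H](NC(=O)OC)C(C)C)cc3)N2c2ccc(C(F)(F)F)cc2)cc1)C(C)C` and compound 2 `COC(=O)N[C@H](C(=O)N1CCC[C@H]1C(=O)Nc1ccc([C@@H]2CC[C@@H](c3ccc(NC(=O)[C@@H]4CCCN4C(=O)[C@@H](NC(=O)OC)[C@@H](C)OC)cc3)N2c2ccc(F)cc2)cc1)[C@@H](C)OC` were examined in an ADME assay on the whole organism for pharmacokinetics, with Rattus norvegicus as the target, at a dose of 3 mg/kg by the intravenous route; a lower number here means that more of the compound stays in the plasma, a higher number that more of the compound sits outside the plasma. Compound 3 gives 2.4 L/kg, the highest of the three numbers, while compound 1 gives 1.3 L/kg and compound 2 gives 1.3 L/kg; both lie within the usual scatter of compound 3, so no order can be drawn among them. Compound 4 `COC(=O)N[C@H](C(=O)N1CCC[C@H]1C(=O)Nc1ccc([C@H]2CC[C@H](c3ccc(NC(=O)[C@@H]4CCCN4C(=O)[C@@H](NC(=O)OC)C(C)C)cc3)N2c2ccc(F)cc2)cc1)C(C)C` is not yet measured. It differs from compound 3 only in configuration as drawn: the two compounds have the same atoms and bonds and differ only in configuration as drawn: 2 of 6 stereo elements differ; a stereocentre at a saturated ring carbon is drawn S in compound 3 and R in compound 4; a stereocentre at a saturated ring carbon is drawn S in compound 3 and R in compound 4. Among the compounds with values here, no step between two measured compounds isolates this change, and all gaps among the three measured values fall within the scatter. The step from compound 3 to compound 4 is therefore expected to be a 1.4-fold lower number from compound 3 to compound 4 (0.15 log units; within the scatter), not beyond the scatter. Compound 4 is estimated to give 1.7 L/kg, within a range from 0.9 L/kg to 3.4 L/kg.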

Compound 4, volume of distribution at steady state: 0.5 L/kg
Estimate against measurement, compound 4: 3.4-fold (0.53 log units) above, and the stated range ends above it.
By their numbers in this assay, from the lowest: compound 4; then compounds 1, 2 and 3 (each within the scatter of the next).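

Among the earlier compounds no step isolated a single change, but in this assay the configuration at the two saturated ring stereocentres now proves to matter, with a 4.8-fold lower number from compound 3 to compound 4 (0.68 log units; beyond the scatter). This step can be laid to those two stereocentres alone, because of one point: the fact that compounds 3 and 4 differ only in the configuration as drawn With the configuration of compound 4 kept, fluoro in place of trifluoromethyl on an aromatic carbon also counts, with a 2.6-fold lower number from compound 1 to compound 4 (0.41 log units; beyond the scatter).

From the compounds shown here alone, it remains open whether the same flip acts alike with the methoxy-bearing side chains of compound 2. Also open, going by these compounds, is what a nitrile or an amine in place of fluoro on that aromatic carbon would give.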